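The source may report more compounds than this note shows. Statements on the series, on what has been measured and on what is new or still open speak of the compounds shown alone.

Measured compounds in a functional assay on Hs-578T cells (Homo sapiens) for cytotoxicity, read by sulforhodamine B assay, with a stated time of 48 h; a higher number here means a weaker inhibitor of growth, a lower number a stronger inhibitor of growth:
Compound 1 `ClCc1ccccc1Cn1cnc2c(Cl)nc(Cl)nc21` gives 3540 nM in this assay.
Compound 2 `ClCc1cccc(Cn2cnc3c(Cl)nc(Cl)nc32)c1` gives 4360 nM in this assay.

Compound 1 has the lowest of the two numbers, but the number for compound 2 lies within the usual scatter of repeated measurements, so the two compounds cannot be told apart on these data. Compound 3 `Nc1nc(Cl)c2ncn(Cc3ccccc3CCl)c2n1` differs from compound 1 in a single place: amino in place of chloro on an aromatic carbon. The rest of the molecule is unchanged. Within the data shown here, no pair of measured compounds shares this change, so nothing here fixes its size or direction; the expectation rests on the shared core and on the single change alone. A small move toward a higher number, not clearly beyond the scatter, is expected: the step from compound 1 to compound 3 is estimated as a 1.4-fold higher number from compound 1 to compound 3 (0.15 log units; within the scatter). Compound 3 is expected to give about 5000 nM in this assay, with a plausible range from 1700 nM to 15000 nM.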

Compound 3, concentration for total growth inhibition: 77600 nM
Beside the measured number, compound 3's estimate is 16-fold (1.19 log units) below it, and the stated range ends below it.
By their numbers in this assay, from the lowest: compounds 1 and 2 (each within the scatter of the next); then compound 3.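

In this assay, the chloro group on the aromatic carbon between two ring nitrogen atoms proves to matter: amino in its place gives a 22-fold higher number from compound 1 to compound 3 (1.34 log units; beyond the scatter) and so a much weaker inhibitor of growth. Compound 1 and compound 2 differ elsewhere in the molecule and say nothing about this carbon, whereas this one exchange of a single heavy atom moves the number far beyond the scatter. Nothing measured here explains why the step is so large.

The compounds shown leave open whether another group on this carbon, such as methoxy, methylamino or plain hydrogen, would stay close to compound 1 or rise as far as compound 3. They also leave open whether amino in place of chloro would bring a similar step on compound 2.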